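Amino for Sulfanyl on the Shared Core

This account rests on a few compounds, and the source may have more. Where it says the series, first, only, none or still open, it means among the compounds named here.

Measured so far:
- compound 1 `Sc1[nH]ccc2ncnc1-2` — < 5%
- compound 2 `OC[C@H]1OC(n2cnc3c(Cl)nccc32)[C@H](O)[C@@H]1O` — < 5%
- compound 3 `c1ccc(Nc2[nH]ccc3ncnc2-3)cc1` — 26%

These notes follow the step from compound 1 to compound 4. In a functional assay on EL4 cells (Mus musculus) for inhibition, tested at 100 uM (a higher number here means more inhibition at the concentration tested (going by the name of the read-out), a lower number less inhibition), compound 1 gives < 5%, which is a limit of the assay and not a number. Compound 2, built on a different scaffold, likewise gives only a limit in this assay, < 5%. Built on the same core as compound 1, compound 3 gives 26% in this assay. Thus compound 1 sits at the floor of the numbers shown, together with one other compound, as noted in the limit of < 5% in this assay, at which 2 of the 3 values shown sit.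

Compound 4 `Nc1[nH]ccc2ncnc1-2` is not yet measured. It differs from compound 1 by amino in place of sulfanyl on an aromatic carbon. Among the compounds with values here, no step between two measured compounds isolates this change, so the expected size rests only on the standing of compound 1 and on compound 3.

Compound 4 is expected to move upward from the limit by a modest step, a number at least 5 percentage points higher from compound 1 to compound 4 (that floor lies within the scatter), a step that may not exceed the scatter. On the same core, compound 3 gives 26%. That value is what the expectation of some inhibition for compound 4 rests on. The estimate for compound 4 in this assay is 10%, with a range from 3% to 25%.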

Compound 4, a percentage reported as inhibition, at one concentration (the size of the read-out at that concentration, not a potency): < 5%
Compound 4 ended at the assay's limit; the forecaster's own chance of this, stated with the estimate: 35%; middle value at least 5 percentage points away from the limit.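

No step can be read between compound 1 and compound 4 in this assay, since both results are limits of the assay and not numbers: the limit of < 5% in this assay, at which 3 of the 4 values shown sit.

The compounds shown leave open whether amino in place of sulfanyl on an aromatic carbon of the shared core changes inhibition at all.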